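A few compounds are considered here, and "the series" means these few. Any claim that something is new, unique, unknown or untested is made for them only; others in the source may bear on it.

In an ADME assay on microsomes from liver (Homo sapiens) for metabolic stability (a lower number here means that the compound disappears faster, a higher number that the compound lasts longer), compound 2 `CC(C)C(CC(N)=O)c1ccc(-c2ccc3cccc(F)c3c2)[nH]c1=O` stands at < 0.0667 h, which is a limit and not a number. Compound 1 `CC(C)C(c1ccc(-c2ccc3cccc(F)c3c2)[nH]c1=O)N1CCCCC1=O` gives 0.183 h. Compound 3 `Cc1c[nH]c(C(c2ccc(-c3ccc4cccc(F)c4c3)[nH]c2=O)C(C)C)n1` carries 4-methyl-1H-imidazol-2-yl in place of carbamoylmethyl on the saturated chain carbon (4-methyl-1H-imidazol-2-yl in place of carbamoylmethyl on a saturated chain carbon bound to an aromatic carbon and a saturated chain carbon). Within the data shown here, the one measured step bearing on this is an at least 2.7-fold lower number from compound 1 to compound 2 (0.43 log units; beyond the scatter), which puts carbamoylmethyl in place of 2-oxopiperidin-1-yl and lies beyond the scatter. Resting on that single step, losing carbamoylmethyl is expected to bring a modest rise in half-life. The expected change is an at least 1.7-fold higher number from compound 2 to compound 3 (0.25 log units; that floor lies within the scatter). The estimate for compound 3 is 0.12 h, with an expected range of 0.05 h to 0.3 h.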

Compound 3, half-life: 0.09 h
For compound 3 the middle estimate is 1.3-fold (0.12 log units) above the measured one; the range from low to high includes it.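

In this assay a ring at this position does not by itself restore the half-life, since 4-methyl-1H-imidazol-2-yl in place of 2-oxopiperidin-1-yl gives a 2.0-fold lower number from compound 1 to compound 3 (0.31 log units; beyond the scatter) and so falls short of compound 1, as carbamoylmethyl does. Against carbamoylmethyl, the new group gives an at least 1.3-fold higher number from compound 2 to compound 3 (0.13 log units; that floor lies within the scatter) with a floor that leaves the size of this gain unsettled. The value of compound 2 is a limit and not a number: the limit of < 0.0667 h in this assay, at which 1 of the 3 values shown sits.

Going by these compounds, it remains open whether an amine or a carboxylic acid on this saturated chain carbon would match compound 1. On these data alone, the effect of the methyl on the imidazole ring also remains open.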